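Substituting the Sulfonyl Aryl Ring Para to the Sulfonyl

The source may hold more compounds than are shown below. What is called first, only, known or untested is meant among the compounds shown, and "the series" means these compounds.

Compound 1 `O=C1C=CC(O)(c2cc3ccccc3n2S(=O)(=O)c2ccccc2)C=C1`: 30 nM
Compound 2 `O=C1C=CC(O)(c2cc3ccc(F)cc3n2S(=O)(=O)c2ccccc2)C=C1`: < 10 nM
Compound 3 `CCOC(=O)Nc1ccc(S(=O)(=O)n2c(C3(O)C=CC(=O)C=C3)cc3ccccc32)cc1`: 295 nM

In a functional assay on HCT-116 cells (Homo sapiens) for inhibition, read by MTT assay, with a stated time of 72 h (a lower number here means that less compound is tolerated, a higher number that more compound is tolerated), compound 1 gives 30 nM, the lowest of the two plain numbers. Compound 2 gives < 10 nM, which is a limit of the assay and not a number. Compound 3 gives 295 nM, and the step of a 9.8-fold higher number from compound 1 to compound 3 (0.99 log units; beyond the scatter) is modest. Compound 4 `COC(=O)CCc1ccc(S(=O)(=O)n2c(C3(O)C=CC(=O)C=C3)cc3ccccc32)cc1` differs from compound 1 by 2-(methoxycarbonyl)ethyl in place of hydrogen on an aromatic carbon. For the measured compounds named here, the measured step that bears on it is the one to compound 3, where a group likewise enters on an aromatic carbon of the same ring; in that step the number rose beyond the scatter, so a rise is expected here too, of about a 5.0-fold higher number from compound 1 to compound 4 (0.70 log units; beyond the scatter). Given a 9.8-fold higher number from compound 1 to compound 3 (0.99 log units; beyond the scatter), compound 4 is expected at 150 nM, within 40 nM to 600 nM.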

Compound 4, concentration lethal to 50% of the cells: 20 nM
Compound 4: middle estimate off by 7.5-fold (0.88 log units), on the high side; the measured number lies below the stated range.
By their numbers in this assay, from the lowest: compounds 4 and 1 (each within the scatter of the next); then compound 3. At a limit, below all of these: compound 2.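

In this assay the step of a 1.5-fold lower number from compound 1 to compound 4 (0.18 log units; within the scatter) shows that this place can carry 2-(methoxycarbonyl)ethyl with no change beyond the scatter. Entry of a group here therefore does not by itself raise the number, as compound 3 alone had suggested; the identity of the group decides, as a 15-fold lower number from compound 3 to compound 4 (1.17 log units; beyond the scatter) shows. Nothing measured here explains the gap between these two groups.

The compounds shown leave open how a carboxylic acid, an amine or a longer chain would read at this place.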